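This account rests on a few compounds, and the source may have more. Where it says the series, first, only, none or still open, it means among the compounds named here.

Compound 2 `COc1ncnc(Nc2ccc(C#N)c(OCC=C(C)C)c2)n1` and compound 1 `CC(C)=CCOc1cc(Nc2ncnc(Cl)n2)ccc1C#N` share one core and differ at a single aromatic carbon, where compound 2 carries a methoxy group and compound 1 a chloro. Within the data shown here, in an ADME assay on MT2 cells (Homo sapiens) for cytotoxicity (on this read-out lower numbers stand for higher toxicity in this test and higher numbers for lower toxicity in this test), compound 2 gives 42000 nM, the only plain number among the two values shown. Compound 1 reaches a limit of this assay, > 100000 nM. Among the measured compounds shown here, the single measured step, an at least 2.3-fold lower number from compound 1 to compound 2 (0.37 log units; beyond the scatter), thus rests on one side on a limit (the limit of > 100000 nM in this assay, at which 1 of the 2 values shown sits). Compound 3 `CC(C)=CCOc1cc(Nc2ncnc(N)n2)ccc1C#N` changes the same aromatic carbon once more: amino in place of methoxy on an aromatic carbon. That one step is all that bears on this change, and it was at least modest, so for compound 3 a change in this assay of at most modest size, in no settled direction, is expected. For compound 3 the estimate is 50000 nM, between 20000 nM and 150000 nM, an expected step of a 1.2-fold higher number from compound 2 to compound 3 (0.08 log units; within the scatter).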

Compound 3, half-maximal cytotoxic concentration: 200 nM
For compound 3 the middle estimate is 250-fold (2.40 log units) above the measured one, outside the stated range (below it).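

Amino in place of methoxy at this aromatic carbon gives a 210-fold lower number from compound 2 to compound 3 (2.32 log units; beyond the scatter), which in this assay means much higher toxicity, so this position is far more sensitive than the earlier chloro-to-methoxy step suggested. Compared with compound 1, amino in place of chloro gives an at least 500-fold lower number from compound 1 to compound 3 (2.69 log units; beyond the scatter), and this step is only a lower bound, as it starts from a limit: the limit of > 100000 nM in this assay, at which 1 of the 3 values shown sits. Compound 3 is the most toxic of the three in this test, and it is the only one of them with a hydrogen-bond donor on this carbon.

Going by these compounds, whether that donor goes with the toxicity remains open. A methylamino or dimethylamino group, or a hydroxyl, on the same carbon would help separate the effect of the donor from that of the amino group as a whole.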